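The source may report more compounds than this note shows. Statements on the series, on what has been measured and on what is new or still open speak of the compounds shown alone.

Measured so far:
- compound 1 `CC(C)c1ccc(NC(=O)N2CCN(c3ncccc3[N+](=O)[O-])CC2)cc1` gives 245 nM in a functional assay on HEK293 cells for antagonist activity at transient receptor potential cation channel subfamily V member 1 (Rattus norvegicus); on this read-out lower numbers stand for stronger inhibition and higher numbers for weaker inhibition
- compound 2 `CCCCc1ccc(NC(=O)N2CCN(c3ncccc3Cl)CC2)cc1` gives 203 nM in this assay

Compound 2 has the lowest of the two numbers, yet its gap to compound 1 lies within the scatter, so the two stand level. Compound 3 `O=C(Nc1ccc([N+](=O)[O-])cc1)N1CCN(c2ncccc2Cl)CC1` differs from compound 2 by nitro in place of butyl on an aromatic carbon. Within the data shown here, no measured pair shows this kind of change, so the direction rests on judgement alone. A moderate weakening is expected, with a step of a 3.9-fold higher number from compound 2 to compound 3 (0.60 log units; beyond the scatter) beyond the scatter but not large. Compound 3 is estimated at 800 nM, within a range from 200 nM to 3000 nM.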

Compound 3, half-maximal inhibitory concentration: > 25000 nM
Compound 3: only a limit was reported; the forecaster's own chance of this, stated with the estimate: 8%; middle value at least 31-fold (1.49 log units) away from the limit.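

At this aromatic carbon, para to a large group, swapping butyl for nitro is far from a mild change: in this assay it gives an at least 120-fold higher number from compound 2 to compound 3 (2.09 log units; beyond the scatter). Compound 3 has only a limit as its reading: the limit of > 25000 nM in this assay, at which 1 of the 3 values shown sits. Among these compounds, compounds 1 and 2 carry only carbon groups at this place, so compound 3 is the first to show that a group of nitrogen and oxygen here can make a large difference.

Going by these compounds, whether the loss of butyl or the arrival of nitro matters more stays open. A longer chain or an amine at this place, on the core of compound 2, would help to separate the two.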